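Working notes: compound 3 to compound 4, ethyl to propyl

The source may hold more compounds than are shown below. What is called first, only, known or untested is meant among the compounds shown, and "the series" means these compounds.

Numbers in a functional assay on M21 cells (Homo sapiens) for antiproliferative activity, read by sulforhodamine B assay, with a stated time of 48 h (a lower number here means a stronger inhibitor, a higher number a weaker inhibitor), for the three measured compounds:
compound 1, `CCN1CCN(c2ccc(S(=O)(=O)Oc3cccc(OC)c3)cc2)C1=O`: 7000 nM
compound 2, `CCN1CCN(c2ccc(S(=O)(=O)Oc3cccc(Br)c3)cc2)C1=O`: 3400 nM
compound 3, `CCN1CCN(c2ccc(S(=O)(=O)Oc3ccc(OC)cc3)cc2)C1=O`: 26000 nM

Compound 3 stands at the highest number of the three. Within the data shown here, the step of a 3.7-fold higher number from compound 1 to compound 3 (0.57 log units; beyond the scatter) and the step of a 7.6-fold higher number from compound 2 to compound 3 (0.88 log units; beyond the scatter) both place it at the weak end of the measured set, and the remaining step, a 2.1-fold lower number from compound 1 to compound 2 (0.31 log units; beyond the scatter), is the only other comparison available. All three steps concern the group carried on the oxygen of the shared core; none of them touches the chain on the ring nitrogen.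

Compound 4, `CCCN1CCN(c2ccc(S(=O)(=O)Oc3ccc(OC)cc3)cc2)C1=O`, differs from compound 3 by methyl in place of hydrogen on a saturated chain carbon, two bonds along the chain from an amide-type nitrogen in a ring — read one bond further out, ethyl to propyl. Among the measured compounds shown here, no measured step bears on this change, so there is nothing in the set that would point to a shift in either direction, and the working expectation is no step beyond the scatter in this assay. The step of no change at the digits printed from compound 3 to compound 4 (within the scatter) is therefore the expected outcome, with a wide range to reflect the lack of a comparable step. For compound 4 the estimated value in this assay is 26000 nM, expected between 9000 nM and 70000 nM.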

Compound 4, half-maximal inhibitory concentration: 23000 nM
For compound 4 the middle estimate is 1.1-fold (0.05 log units) above the measured one; measured number inside the range.
By their numbers in this assay, from the lowest: compound 2; then compound 1; then compounds 4 and 3 (each within the scatter of the next).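

In this assay, among these compounds, the step of a 1.1-fold lower number from compound 3 to compound 4 (0.05 log units; within the scatter) gives the first reading on the chain on the ring nitrogen, as all earlier steps concerned the group on the oxygen of the shared core. With 4-methoxyphenyl held on the oxygen, ethyl to propyl stays within the scatter, so this change moves the number far less than the earlier changes on the oxygen, all of which were printed as beyond the scatter. No supporting measurement is available to account for this result.

On these data alone, the propyl chain appears here only with 4-methoxyphenyl on the oxygen, so it remains open whether the same flat reading would hold with 3-bromophenyl or 3-methoxyphenyl, the two groups that carry the lower numbers with ethyl. Also open, as far as these compounds go, is the reach of this position: a longer chain such as butyl, a branched isopropyl, or a chain ending in an amine or a carboxylic acid could each read differently in this assay.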